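Adding a Chloro Group to the Shared Core

A few compounds are considered here, and "the series" means these few. Any claim that something is new, unique, unknown or untested is made for them only; others in the source may bear on it.

Compound 1 `O=C1Nc2ccccc2/C1=C\c1c(Cl)n(Cc2ccccc2)c2ccccc12` and compound 2 `O=C1Nc2ccccc2/C1=C\c1c(Cl)n(CCCc2ccccc2)c2ccccc12` have both been measured in a functional assay on cells (Cancer cell lines, Homo sapiens) for cytotoxicity, with a stated time of 48 h; a higher number here means a weaker inhibitor of growth, a lower number a stronger inhibitor of growth. Compound 1 gives 20400 nM, while compound 2 gives 13800 nM; the step between them is a 1.5-fold lower number from compound 1 to compound 2 (0.17 log units; within the scatter). Compound 2 thus stands within the scatter of compound 1, and neither is separated from the other. Compound 3 `O=C1Nc2ccc(Cl)cc2/C1=C\c1c(Cl)n(CCCc2ccccc2)c2ccccc12` differs from compound 2 by chloro in place of hydrogen on an aromatic carbon. Within the data shown here, no measured step involves a change of this kind; the only known step concerns a chain, not a ring substituent, so no shift beyond the scatter is expected in this assay. Compound 3 is therefore estimated at 10000 nM. For compound 3 the range is expected to run from 3000 nM to 35000 nM. This means an expected step of a 1.4-fold lower number from compound 2 to compound 3 (0.14 log units; within the scatter).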

Compound 3, concentration for 50% growth inhibition: 1860 nM
The estimate for compound 3 lay 5.4-fold (0.73 log units) above the measured number; the measured number lies below the stated range.
By their numbers in this assay, from the lowest: compound 3; then compounds 2 and 1 (each within the scatter of the next).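

In this assay, among these compounds, chloro in place of hydrogen on an aromatic carbon gives a 7.4-fold lower number from compound 2 to compound 3 (0.87 log units; beyond the scatter) and is the first change here to reach beyond the scatter. The two compounds with different chains on the shared core had stayed within the scatter of each other, so this ring carbon is a place where one added atom can shift growth inhibition. No available evidence explains this step. Going by these compounds, whether fluoro, methoxy or an amine at this carbon would act like chloro remains open. So does whether chloro would give a similar step on compound 1.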